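Methoxy in place of hydrogen on compound 3

A few compounds are considered here, and "the series" means these few. Any claim that something is new, unique, unknown or untested is made for them only; others in the source may bear on it.

In a functional assay on PC-3 cells (Homo sapiens) for inhibition, read by sulforhodamine B assay (on this read-out higher numbers stand for weaker inhibition of growth and lower numbers for stronger inhibition of growth), compound 3 (`COc1ccc(-c2ccc(-c3ccc(-c4nc5ccccc5[nH]4)cc3)cc2)cc1OC`) gives 47100 nM and stands at the high end of the numbers, together with compound 2 (`Oc1ccc(-c2ccc(-c3ccc(-c4nc5ccccc5[nH]4)cc3)cc2)cc1`) at 47000 nM within the scatter. Compound 1 (`COc1cc(-c2ccc(-c3ccc(-c4nc5cc(C)ccc5[nH]4)cc3)cc2)cc(OC)c1OC`) gives 180 nM on the same read-out, a far lower number than either.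

Compound 4 (`COc1cc(-c2ccc(-c3ccc(-c4nc5ccccc5[nH]4)cc3)cc2)cc(OC)c1OC`) follows from compound 3 by methoxy in place of hydrogen on an aromatic carbon ortho to a methoxy group and meta to a large group.

Among the measured compounds shown here, one measured step bears on this ring: 3,4-dimethoxyphenyl in place of 4-hydroxyphenyl gave a 1.0-fold higher number from compound 2 to compound 3 (0.00 log units; within the scatter) and so offers no direction. Compound 1 at 180 nM is the stronger guide: its ring carries the methoxy groups that compound 4 would carry, though the two differ elsewhere on the core, and no measurement isolates that difference. A step to a lower number in this assay is therefore expected, beyond the scatter but probably short of the full gap to compound 1. The expected step is a 39-fold lower number from compound 3 to compound 4 (1.59 log units; beyond the scatter) in the direction of stronger inhibition of growth. For compound 4 the estimated value is 1200 nM with 150 nM to 15000 nM as the expected range.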

Compound 4, concentration for 50% growth inhibition: 9720 nM
Beside the measured number, compound 4's estimate is 8.1-fold (0.91 log units) below it, and the stated range covers the measured number.
By their numbers in this assay, from the lowest: compound 1; then compound 4; then compounds 2 and 3 (each within the scatter of the next).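

In this assay, the third methoxy at this aromatic carbon, ortho to a methoxy group and meta to a large group, gives a readable change: a 4.8-fold lower number from compound 3 to compound 4 (0.69 log units; beyond the scatter). Among the compounds shown here, the earlier step on this ring, a 1.0-fold higher number from compound 2 to compound 3 (0.00 log units; within the scatter), gave no direction, so this is the first sign that substitution on this ring can move the number. For the compounds shown here, with the ring unchanged, the step at the other place is labelled large, against modest for the methoxy step: hydrogen in place of methyl on an aromatic carbon of the shared core gives a 54-fold higher number from compound 1 to compound 4 (1.73 log units; beyond the scatter), so the methyl, which the earlier compounds could not separate from the ring pattern, matters on its own. Nothing available accounts for either step.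

From the compounds shown here alone, whether the change at this aromatic carbon is particular to methoxy remains open; an ethoxy group, a hydroxy group or an amine at the same carbon would test that. Going by these compounds, it is also open whether the methyl step is particular to methyl, which an ethyl group or a chlorine atom on the same carbon of the core would show, and whether it holds with the ring of compound 3.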